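Amide nitrogen substituent: from propyl to chloro-methoxyphenyl

A few compounds are considered here, and "the series" means these few. Any claim that something is new, unique, unknown or untested is made for them only; others in the source may bear on it.

Values in a functional assay on SH-SY5Y cells (Homo sapiens), read by MTT assay, with a stated time of 24 h; on this read-out higher numbers stand for an effect only at larger amounts of compound and lower numbers for an effect already at smaller amounts:
Compound 1 `COc1ccc(NC(=O)CN(c2cc(Cl)ccc2OC)S(=O)(=O)c2ccccc2)cc1` gives 16200 nM.
Compound 2 `CCCNC(=O)CN(c1cc(Cl)ccc1OC)S(=O)(=O)c1ccccc1` gives > 20000 nM, a limit of the assay and not a number.
Compound 3 `COc1ccc(Cl)cc1N(CC(=O)Nc1ccccc1)S(=O)(=O)c1ccccc1` gives > 20000 nM, likewise a limit of the assay.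

Going by the values given here, compound 2 therefore stands at the limit of this assay; the only finite number in the set is that of compound 1, and the measured comparisons are thin: two of the three values sit at the limit of > 20000 nM in this assay, at which 2 of the 3 values shown sit.

Compound 4 `COc1ccc(Cl)cc1NC(=O)CN(c1cc(Cl)ccc1OC)S(=O)(=O)c1ccccc1` carries the change (5-chloro-2-methoxyphenyl in place of propyl on an amide-type nitrogen). Among the compounds with values here, two measured steps touch this place. The step from compound 1 to compound 2 is an at least 1.2-fold higher number from compound 1 to compound 2 (0.09 log units; that floor lies within the scatter), so removing the 4-methoxyphenyl for propyl cost at least a little; the step from compound 2 to compound 3 is a step that the two limits leave unreadable from compound 2 to compound 3, so putting phenyl back reads nothing. An aryl group with a methoxy acceptor, as in compound 1, gave the one finite value 16200 nM; the 5-chloro-2-methoxyphenyl of compound 4 is also an aryl with one acceptor, but carries a chlorine in addition, for which no step is shown.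

Compound 4 is therefore expected near the edge of the assay, estimated at 20000 nM (range 8000 nM to 50000 nM). This estimate means a step of a number no higher from compound 2 to compound 4 (the limit leaves the size open), with a real chance that compound 4 is again reported only as a limit.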

Compound 4, half-maximal effective concentration: > 20000 nM
Compound 4: no number, only a limit; the forecaster's own chance of this, stated with the estimate: 60%; the middle value lies on the limit itself.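

In this assay compound 4 gives > 20000 nM as a limit of the assay and not a number. Going by these compounds alone, an aryl group with a methoxy on the amide-type nitrogen therefore does not by itself yield a finite reading: 5-chloro-2-methoxyphenyl goes against that idea, compound 1 stays the only member with a number, and the change from 4-methoxyphenyl reads as an at least 1.2-fold higher number from compound 1 to compound 4 (0.09 log units; that floor lies within the scatter) and leaves the true size open. The steps to compound 4 from compound 2 and from compound 3 cannot be read, and the series now gathers at one limit: the limit of > 20000 nM in this assay, at which 3 of the 4 values shown sit.

Open, from the compounds shown here alone, is whether a longer chain in place of propyl, or an amine or a carboxylic acid on the aryl group at this nitrogen, would bring a value inside the range of the assay. Also open is what the chlorine of 5-chloro-2-methoxyphenyl contributes on its own, since no pair shown separates it from the methoxy.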